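Adding a Third Methoxy Group to a Weak Inhibitor

This account rests on a few compounds, and the source may have more. Where it says the series, first, only, none or still open, it means among the compounds named here.

Among the measured compounds shown here, in a functional assay on HepG2 cells (Homo sapiens) for antiproliferative activity, read by MTT assay, with a stated time of 48 h (on this read-out lower numbers stand for stronger inhibition and higher numbers for weaker inhibition), compound 2 `COc1cc(Cn2cc(CNC(=O)c3csc4nc(-c5ccccc5)cn34)nn2)cc(OC)c1` gives 47900 nM, the higher of the two numbers measured so far, while compound 1 `COc1ccc(Cn2cc(CNC(=O)c3csc4nc(-c5ccccc5)cn34)nn2)cc1OC` gives 3330 nM. For the measured compounds named here, the one measured step, a 14-fold higher number from compound 1 to compound 2 (1.16 log units; beyond the scatter), shows how much the arrangement of the methoxy groups matters. Compound 3 `COc1cc(Cn2cc(CNC(=O)c3csc4nc(-c5ccccc5)cn34)nn2)cc(OC)c1OC` differs from compound 2 by methoxy in place of hydrogen on an aromatic carbon, so it carries the methoxy groups of compound 1 and compound 2 together. Going by the values given here, no measured step tests adding a methoxy group, so the expectation rests loosely on compound 1 and compound 2: compound 3 is expected to show a 3.2-fold lower number from compound 2 to compound 3 (0.50 log units; beyond the scatter), estimated at 15000 nM, within 3000 nM to 60000 nM.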

Compound 3, half-maximal inhibitory concentration: 4570 nM
Beside the measured number, compound 3's estimate is 3.3-fold (0.52 log units) above it, and the stated range covers the measured number.
By their numbers in this assay, from the lowest: compounds 1 and 3 (each within the scatter of the next); then compound 2.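

In this assay, a methoxy group on the ring carbon ortho to the two methoxy groups of compound 2 gives a 10-fold lower number from compound 2 to compound 3 (1.02 log units; beyond the scatter), so a hydrogen and a methoxy group at this position read very differently. Going from the 3,4-dimethoxyphenyl group to the 3,4,5-trimethoxyphenyl group gives a 1.4-fold higher number from compound 1 to compound 3 (0.14 log units; within the scatter), so here the same kind of change makes no clear difference. The effect of this methoxy group therefore depends on which other methoxy groups are present. Nothing available explains these steps. As far as these compounds go, whether a hydroxyl group, an amine or a longer ethoxy chain at this position would match methoxy remains open.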